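Sulfonyl substituent change on the shared core

A few compounds are considered here, and "the series" means these few. Any claim that something is new, unique, unknown or untested is made for them only; others in the source may bear on it.

Measured so far:
compound 1 `O=C(NCc1ccc(S(=O)(=O)c2cccc(C(F)(F)F)c2)cc1)N1Cc2ccncc2C1`: 8 nM
compound 2 `CC(=O)N1CCC(S(=O)(=O)c2ccc(CNC(=O)N3Cc4ccncc4C3)cc2)CC1`: 83 nM

Both compounds were read in an assay on isolated protein for inhibition of Nicotinamide phosphoribosyltransferase (Homo sapiens), read by mass spectrometry, with stated times of 15 min and 30 min; a lower number here means a stronger inhibitor, a higher number a weaker inhibitor. Compound 1 holds the lowest of the two numbers; its nearest neighbour is compound 2, separated by the step of a 10-fold higher number from compound 1 to compound 2 (1.02 log units; beyond the scatter), which is large and beyond the scatter. Among the compounds with values here, the only change in that step is on the sulfonyl sulfur: 1-acetylpiperidin-4-yl in place of 3-(trifluoromethyl)phenyl.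

Compound 3 `CCC(=O)N1CCC(S(=O)(=O)c2ccc(CNC(=O)N3Cc4ccncc4C3)cc2)CC1` is the next candidate. Relative to compound 1 it differs as follows: 1-propanoylpiperidin-4-yl in place of 3-(trifluoromethyl)phenyl on a sulfonyl sulfur

Within the data shown here, the step from compound 1 to compound 2 is the one measured step that bears on this change, since compound 3 carries the same piperidin-4-yl on the sulfonyl sulfur and differs from compound 2 only in the propanoyl on its nitrogen in place of acetyl. That step was a large move to a higher number. A move of similar size and direction is therefore expected for compound 3, an 11-fold higher number from compound 1 to compound 3 (1.03 log units; beyond the scatter), with no basis in the data for the propanoyl to shift it further either way. Compound 3 is estimated at 85 nM, within a range of 30 nM to 250 nM.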

Compound 3, half-maximal inhibitory concentration: 27 nM
Beside the measured number, compound 3's estimate is 3.1-fold (0.50 log units) above it; measured number below the stated range.
By their numbers in this assay, from the lowest: compound 1; then compound 3; then compound 2.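

In this assay, the piperidin-4-yl group on the sulfonyl sulfur proves far less uniformly costly than the first pair suggested: the 1-propanoyl form gives a 3.4-fold higher number from compound 1 to compound 3 (0.53 log units; beyond the scatter), a modest step, whereas the 1-acetyl form gave a 10-fold higher number from compound 1 to compound 2 (1.02 log units; beyond the scatter), a large one. The acyl part of this substituent therefore affects the read-out, since a single added methyl on the saturated chain carbon bound to the carbonyl carbon gives a 3.1-fold lower number from compound 2 to compound 3 (0.49 log units; beyond the scatter), recovering part of the loss while compound 1 keeps the lowest number of the three. Nothing available here accounts for the gain from that methyl or for the remaining gap to the 3-(trifluoromethyl)phenyl group.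

On these data alone, two acyl groups do not establish a trend, so it remains open whether a longer chain such as butanoyl, or a branched or cyclic acyl group such as isobutyryl or cyclopropanecarbonyl, would lower the number further or reverse the gain. As far as these compounds go, it is also open how much of the standing of compound 1 belongs to the trifluoromethyl group and how much to the aromatic ring, a question that an unsubstituted phenyl group on the sulfonyl sulfur would address.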